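The source may report more compounds than this note shows. Statements on the series, on what has been measured and on what is new or still open speak of the compounds shown alone.

In a functional assay on HCT-116 cells (Homo sapiens) for cytotoxicity, read by MTT assay (on this read-out higher numbers stand for weaker inhibition and lower numbers for stronger inhibition), compound 1 `Cc1c(O)cc(CCCCC(C)C)oc1=O` gives > 200000 nM as a limit of the assay, not a number. Compound 2 `CC(=O)C(C)CCCCc1cc(O)c(C)c(=O)o1` likewise gives > 200000 nM as a limit, not a number. Compound 2 thus has no measured value to start from, only a shared limit (the limit of > 200000 nM in this assay, at which 2 of the 2 values shown sit). Among the measured compounds shown here, the one measured step that bears on the change is a step that the two limits leave unreadable from compound 1 to compound 2 and it offers no size to carry forward. Compound 3 `Cc1c(O)cc(CCCC(C)C)oc1=O` carries isopropyl in place of 2-acetylpropyl on a saturated chain carbon, three bonds along the chain from an aromatic carbon. In this assay the estimate is a number no higher from compound 2 to compound 3 (the limit leaves the size open) and nothing beyond the scatter is expected in either direction. Compound 3 is estimated at 200000 nM with an expected range of 100000 nM to 400000 nM and may well read as a limit again.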

Compound 3, half-maximal inhibitory concentration: > 200000 nM
Compound 3 was reported as a limit; the forecaster's own chance of this, stated with the estimate: 85%; the middle value lies on the limit itself.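

In this assay compound 3 gives > 200000 nM, a limit and not a number. Among the compounds shown here, no step from compound 1 or compound 2 to compound 3 can be read: the limit of > 200000 nM in this assay, at which 3 of the 3 values shown sit. None of the three compounds gives a number, which leaves open whether changing the side chain on the shared core moves this read-out at all.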